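A few compounds are considered here, and "the series" means these few. Any claim that something is new, unique, unknown or untested is made for them only; others in the source may bear on it.

In an assay on CHO cells for displacement of a labelled ligand from adenosine receptor A2b (Homo sapiens), read by scintillation counting, with a stated time of 75 min, in the presence of a further agent that is not named here (a higher number here means a weaker inhibitor, a lower number a stronger inhibitor), the measured compounds stand as follows:

Compound 1, `CCCn1c(=O)[nH]c2nc(-c3ccc(S(=O)(=O)N4CCN(Cc5cccc(C)c5)CC4)cc3)[nH]c2c1=O`: 0.397 nM
Compound 2, `CCCn1c(=O)[nH]c2nc(-c3ccc(S(=O)(=O)N4CCN(c5cccc(Cl)c5)CC4)cc3)[nH]c2c1=O`: 0.342 nM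
Compound 3, `CCCn1c(=O)[nH]c2nc(-c3ccc(S(=O)(=O)N4CCN(c5cccc(F)c5)CC4)cc3)[nH]c2c1=O`: 0.632 nM

Compound 3 shows the highest of these three numbers, yet its gaps to compound 1 and to compound 2 both lie within the scatter, so no order among the three can be claimed. Compound 4, `CCCn1c(=O)[nH]c2nc(-c3ccc(S(=O)(=O)N4CCN(c5ccccc5)CC4)cc3)[nH]c2c1=O`, differs from compound 3 by hydrogen in place of fluoro on an aromatic carbon. All three measured steps bear on this change, since each swaps one group on the same ring: a 1.8-fold higher number from compound 2 to compound 3 (0.27 log units; within the scatter), a 1.6-fold higher number from compound 1 to compound 3 (0.20 log units; within the scatter) and a 1.2-fold lower number from compound 1 to compound 2 (0.06 log units; within the scatter), every one within the scatter. Taking away the fluoro is therefore expected to give no step beyond the scatter in this assay. Compound 4 is expected to give 0.5 nM, with a range from 0.25 nM to 1.2 nM. That estimate amounts to an expected 1.3-fold lower number from compound 3 to compound 4 (0.10 log units; within the scatter).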

Compound 4, inhibition constant: 0.643 nM
Compound 4: middle estimate off by 1.3-fold (0.11 log units), on the low side, and the stated range covers the measured number.
By their numbers in this assay, from the lowest: compounds 2, 1, 3 and 4 (each within the scatter of the next).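

In this assay, the step that removes the fluoro is a 1.0-fold higher number from compound 3 to compound 4 (0.01 log units; within the scatter), and the other two new steps read a 1.9-fold higher number from compound 2 to compound 4 (0.27 log units; within the scatter) and a 1.6-fold higher number from compound 1 to compound 4 (0.21 log units; within the scatter). The unsubstituted phenyl group thus shows that neither fluoro nor chloro on this aromatic carbon is required for a value in this range. Nothing available gives a reason for this. On these data alone, whether an amine, a carboxylic acid or a methoxy group at this place would also stay within the scatter remains open.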